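Aromatic isoquinoline in place of the saturated bicyclic amine

The compounds below may be only part of what the source reports. "The series", "measured", "known", "first", "only" and "open" are said of these compounds alone.

Compound 1 `c1ccc2c(c1)CN[C@H](CN(CCCN1CCNCC1)[C@H]1CCCc3cccnc31)C2`: 88%
Compound 2 `c1ccc2c(c1)CN[C@@H](CN(CCC1CCNCC1)[C@H]1CCCc3cccnc31)C2`: 17%

In an ADME assay on microsomes from liver (Rattus norvegicus) for metabolic stability, read by LC-MS, with a stated time of 10 min, tested at 0.5 uM (on this read-out lower numbers stand for a less stable compound and higher numbers for a more stable compound), compound 1 gives the higher of the two numbers, standing well above compound 2, whose value of 17% lies beyond the scatter from it. Compound 3 `c1cnc2c(c1)CCC[C@@H]2N(CCCN1CCNCC1)Cc1cc2ccccc2cn1` differs from compound 1 in one place: isoquinolin-3-yl in place of 1,2,3,4-tetrahydroisoquinolin-3-yl on a saturated chain carbon bound to an amine nitrogen. Going by the values given here, no measured pair shows this change, so its size is uncertain. Because compound 1 already gives 88%, little room remains upward; a small downward step is expected, possibly within the scatter. Compound 3 is estimated at 75%, between 45% and 95%, a step of a number 13 percentage points lower from compound 1 to compound 3 (beyond the scatter).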

Compound 3, percent of the compound remaining: 59%
Beside the measured number, compound 3's estimate is 16 percentage points above it, and the stated range covers the measured number.
By their numbers in this assay, from the lowest: compound 2; then compound 3; then compound 1.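

In this assay, isoquinolin-3-yl in place of 1,2,3,4-tetrahydroisoquinolin-3-yl on a saturated chain carbon bound to an amine nitrogen gives a number 29 percentage points lower from compound 1 to compound 3 (beyond the scatter), so the read-out responds to a change at this place. The change also removes the hydrogen-bond donor and the defined stereocentre of the leaving group, and this single step cannot separate these differences from the change of ring. No measurement given here accounts for the step. The compounds shown leave open whether a methyl group on the ring nitrogen of 1,2,3,4-tetrahydroisoquinolin-3-yl, which would remove the donor and keep the non-aromatic ring, would give a similar number.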